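A few compounds are considered here, and "the series" means these few. Any claim that something is new, unique, unknown or untested is made for them only; others in the source may bear on it.

Of the compounds shown here, three of a shared core have been measured in an assay on isolated protein for displacement of a labelled ligand from 5-hydroxytryptamine receptor 6 (Homo sapiens) (a lower number here means a stronger inhibitor, a higher number a weaker inhibitor), so far. Compound 1 `CNCC1CCCc2cc(S(=O)(=O)c3ccccc3)ccc21` gives 0.316 nM and compound 2 `NC[C@@H]1CCCc2cc(S(=O)(=O)c3cccc(O)c3)ccc21` gives 0.251 nM in this assay, while compound 3 `O=S(=O)(c1cccc(F)c1)c1ccc2c(c1)CCC[C@H]2CN1CCCS1(=O)=O` gives 31.6 nM, the highest of the three numbers and beyond the scatter from both of the others. Compound 4 `COC(=O)NC[C@@H]1CCCc2cc(S(=O)(=O)c3cccc(F)c3)ccc21` is not yet measured; it differs from compound 3 by a group of 5 heavy atoms (2 carbon, 1 nitrogen, 2 oxygen; no ring) in place of a group of 7 heavy atoms (3 carbon, 1 nitrogen, 2 oxygen, 1 sulfur; one five-membered non-aromatic ring with 2 hetero atoms), on a saturated chain carbon bound to a saturated ring carbon. Among the compounds with values here, with no measured pair showing this exact change, the expectation rests on compound 3 alone, whose value of 31.6 nM leaves room downward toward compounds 1 and 2. Compound 4 is expected to land at 8 nM, between 2 nM and 40 nM. That estimate means a step of a 4.0-fold lower number from compound 3 to compound 4 (0.60 log units; beyond the scatter), a moderate move to a lower number.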

Compound 4, inhibition constant: 1.59 nM
For compound 4 the middle estimate is 5.0-fold (0.70 log units) above the measured one, outside the stated range (below it).
By their numbers in this assay, from the lowest: compounds 2 and 1 (each within the scatter of the next); then compound 4; then compound 3.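

On the saturated chain carbon bound to a saturated ring carbon, the group matters greatly in this assay: (methoxycarbonyl)amino in place of the five-membered ring gives a 20-fold lower number from compound 3 to compound 4 (1.30 log units; beyond the scatter), a large step. The entering group has no ring and adds a hydrogen-bond donor, and this one pair cannot separate those two differences. No measurement given here accounts for the step. Still open, from the compounds shown here alone, is how an acetamide or an (ethoxycarbonyl)amino group would compare at this place.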